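Three Limits and One Untested Compound

A few compounds are considered here, and "the series" means these few. Any claim that something is new, unique, unknown or untested is made for them only; others in the source may bear on it.

Compound 1 `COC1=CC(=O)C(O)=C(C/C=C(\C)CC[C@@]2(C)CCC=C(C)[C@H]2C)C1=O` was tested in an ADME assay on KB cells (Homo sapiens) for cytotoxicity, with a stated time of 48 h; a lower number here means a stronger inhibitor, a higher number a weaker inhibitor. In this assay compound 1 gives only a limit of > 10 ug/mL. Compound 2 `C=C1[C@H](C)CCC[C@]1(C)CC/C(C)=C/CC1=C(O)C(=O)C=C(N[C@H](C(=O)O)[C@H](C)O)C1=O` in this assay likewise reaches only the limit > 10 ug/mL. Compound 3 `C=C1[C@H](C)CCC[C@]1(C)CC/C(C)=C/CC1=C(O)C(=O)C=C(N[C@@H](C(=O)O)[C@@H](C)O)C1=O` in this assay also stops at the limit > 10 ug/mL. So compound 1 stands together with the other two at the limit, and none of the three gives a number. For the measured compounds named here, the one change among measured pairs, a step that the two limits leave unreadable from compound 2 to compound 3, cannot be read, because the limit of > 10 ug/mL in this assay, at which 3 of the 3 values shown sit, and the fact that compounds 2 and 3 differ only in the configuration as drawn leave it without a size. Compound 4 `CC1=CCC[C@](C)(CC/C(C)=C/CC2=C(O)C(=O)C=C(N[C@@H](CO)C(=O)O)C2=O)[C@@H]1C` differs from compound 1 by (1-carboxy-2-hydroxyethyl)amino in place of methoxy on a double-bonded ring carbon. Going by the values given here, no measured step bears on this change, so no size in this assay can be taken from the data; compound 2 and compound 3, which carry a related amino group in place of methoxy, give only limits. Compound 4 is therefore expected to remain at the limit, with the step that the limit leaves unreadable from compound 1 to compound 4 expected to be small, if any. The estimate for compound 4 is 15 ug/mL with a range from 5 ug/mL to 50 ug/mL.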

Compound 4, half-maximal inhibitory concentration: > 10 ug/mL
Compound 4 ended at the assay's limit; the forecaster's own chance of this, stated with the estimate: 80%; the middle value lies beyond the limit too.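

Compound 4 stops at a limit in this assay, as compound 1 does, so no size can be read for the change between compound 1 and compound 4: the limit of > 10 ug/mL in this assay, at which 4 of the 4 values shown sit.

The compounds shown leave open whether (1-carboxy-2-hydroxyethyl)amino in place of methoxy changes the read-out at all, since none of the four gives a number in this assay.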